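Aryl amide swap on the shared core

The source may report more compounds than this note shows. Statements on the series, on what has been measured and on what is new or still open speak of the compounds shown alone.

Compound 1 `COc1ccc(C(=O)Nc2ccccc2F)cc1OC1CCCC1` carries a 2-fluorophenyl on the amide nitrogen and gives 10700 nM in an assay on isolated protein for inhibition of phosphodiesterase 4A (Sus scrofa) (on this read-out higher numbers stand for weaker inhibition and lower numbers for stronger inhibition), the highest of the two numbers measured in that assay. Compound 3 `COc1ccc(C(=O)Nc2c(F)cnc(F)c2F)cc1OC1CCCC1` sits nearest with 85 nM in this assay, a lower number beyond the scatter. Compound 2 `COc1ccc(C(=O)Oc2c(Cl)cccc2Cl)cc1OC1CCCC1` is an ester rather than an amide and in this assay gives only a limit, > 1000000 nM, consistent with the limit of > 1000000 nM in this assay, at which 1 of the 3 values shown sits.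

Compound 4 `COc1ccc(C(=O)Nc2c(C)nsc2C#N)cc1OC1CCCC1` is not yet measured. The change from compound 1 is 5-cyano-3-methyl-1,2-thiazol-4-yl in place of 2-fluorophenyl on an amide-type nitrogen. For the measured compounds named here, no measured step covers this change; on the showing of compound 3, whose 85 nM came with a hetero-substituted amide aryl, the step is expected to lower the number beyond the scatter. For compound 4 the estimate is 1500 nM (range 250 nM to 9000 nM), an expected step of a 7.1-fold lower number from compound 1 to compound 4 (0.85 log units; beyond the scatter).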

Compound 4, half-maximal inhibitory concentration: 200 nM
Compound 4: middle estimate off by 7.5-fold (0.88 log units), on the high side; the measured number lies below the stated range.
By their numbers in this assay, from the lowest: compound 3; then compound 4; then compound 1. At a limit, above all of these: compound 2.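

The amide nitrogen of the shared core accepts a five-membered aromatic ring with 2 hetero atoms in place of 2-fluorophenyl, and inhibition does not fall away: in this assay this swap gives a 54-fold lower number from compound 1 to compound 4 (1.73 log units; beyond the scatter) and so counts as a large step. A six-membered ring is therefore not required at this place. Nothing at hand explains the size of this step.

The compounds shown do not separate the contributions of the nitrile, the methyl and the ring itself. Going by these compounds, how an amine or a carboxylic acid on the ring at this place would read also remains open.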